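Working notes: from compound 2 to compound 4

The source may report more compounds than this note shows. Statements on the series, on what has been measured and on what is new or still open speak of the compounds shown alone.

Measured in a functional assay on MCF7 cells (Homo sapiens) for antiproliferative activity, read by CCK-8 assay, with a stated time of 48 h; a higher number here means a weaker inhibitor, a lower number a stronger inhibitor
- compound 1 `CNC(=O)/C=C/CN1CC(Oc2ccc(Oc3c(-c4ccc(F)cc4)sc4cc(O)ccc34)cc2)C1` gives > 25000 nM (a limit, not a number)
- compound 2 `C/C=C/C(=O)N1CC(Oc2ccc(Oc3c(-c4ccc(F)cc4)sc4cc(O)ccc34)cc2)C1` gives 28000 nM
- compound 3 `CNC(=O)/C=C/CNCCOc1ccc(Oc2c(-c3ccc(F)cc3)sc3cc(O)ccc23)cc1` gives 16100 nM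

Among the measured compounds shown here, compound 2 holds one of only two readable numbers in this assay and has no readable neighbour other than compound 3. The gap between those two stays small (a 1.7-fold lower number from compound 2 to compound 3 (0.24 log units; within the scatter)). Compound 1 offers no number (the limit of > 25000 nM in this assay, at which 1 of the 3 values shown sits).

Compound 4 `O=C(/C=C/CN1CC(Oc2ccc(Oc3c(-c4ccc(F)cc4)sc4cc(O)ccc34)cc2)C1)N1CCCC1` is still to be measured. Its change from compound 2 is this: 3-((pyrrolidin-1-yl)carbonyl)prop-2-en-1-yl in place of (prop-1-en-1-yl)carbonyl on an amine nitrogen in a ring. In words, 3-((pyrrolidin-1-yl)carbonyl)prop-2-en-1-yl stands in place of (prop-1-en-1-yl)carbonyl on an amine nitrogen in a ring, and the entering group brings one five-membered non-aromatic ring.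

For the measured compounds named here, the one measured step at that nitrogen gives no size (a step that the limit leaves unreadable from compound 1 to compound 2). The remaining step, made at the oxygen on the aromatic ring, also stays within the scatter (an at least 1.5-fold lower number from compound 1 to compound 3 (0.19 log units; that floor lies within the scatter)). With compound 3 reached from compound 2 only within the scatter (a 1.7-fold lower number from compound 2 to compound 3 (0.24 log units; within the scatter)), no step beyond the scatter is expected in this assay, in either direction. The expected step is small (a 1.1-fold lower number from compound 2 to compound 4 (0.05 log units; within the scatter)). Compound 4 is estimated at 25000 nM (expected range 10000 nM to 50000 nM).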

Compound 4, half-maximal inhibitory concentration: 8450 nM
The estimate for compound 4 lay 3.0-fold (0.47 log units) above the measured number; the whole stated range lies above it.
By their numbers in this assay, from the lowest: compounds 4, 3 and 2 (each within the scatter of the next, the first and the last beyond it).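

In this assay, the amine nitrogen in the four-membered ring now gives its first step of readable size, with 3-((pyrrolidin-1-yl)carbonyl)prop-2-en-1-yl in place of (prop-1-en-1-yl)carbonyl: a 3.3-fold lower number from compound 2 to compound 4 (0.52 log units; beyond the scatter). The carbonyl carbon of the side chain on that nitrogen also proves to be a place where one change can be read, since pyrrolidin-1-yl in place of methylamino gives an at least 2.9-fold lower number from compound 1 to compound 4 (0.47 log units; beyond the scatter), a floor on the step and not its full size. That floor rests on compound 1, which has a limit and not a number: the limit of > 25000 nM in this assay, at which 1 of the 4 values shown sits.

The compounds shown do not separate the ring of pyrrolidin-1-yl from the simple replacement of methylamino, so it stays open whether piperidin-1-yl, morpholin-4-yl or dimethylamino on the same carbonyl carbon would give a similar number. As far as these compounds go, it also stays open whether pyrrolidin-1-yl in place of methylamino gives a step of similar size on the open-chain side arm of compound 3.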